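Compound 2 and its hydroxy replacement

The compounds below may be only part of what the source reports. "The series", "measured", "known", "first", "only" and "open" are said of these compounds alone.

Going by the values given here, in a functional assay on MCF7 cells (Homo sapiens) for cytotoxicity, read by MTT assay, with a stated time of 72 h (a lower number here means a stronger inhibitor, a higher number a weaker inhibitor), compound 2 (`COc1ccc(/C=C2\CCC/C(=C\c3ccc(Cl)cc3)C2=O)cc1OC`) gives 6300 nM as the only number so far. Compound 1 (`COc1cccc(/C=C2\CCC/C(=C\c3ccc(Cl)cc3Cl)C2=O)c1OC`) reads > 20000 nM as a limit and not a number. Compound 3 (`COc1ccc(/C=C2\CCC/C(=C\c3ccc(O)cc3)C2=O)cc1OC`) carries hydroxy in place of chloro on an aromatic carbon, para to a large group (hydroxy in place of chloro on an aromatic carbon). Among the compounds with values here, no measured step in this assay bears on this change, so only a small step towards stronger inhibition is expected, perhaps none beyond the scatter. The expected step (a 1.3-fold lower number from compound 2 to compound 3 (0.10 log units; within the scatter)) stays modest. For compound 3 the estimated value is 5000 nM (expected range 1500 nM to 18000 nM).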

Compound 3, half-maximal inhibitory concentration: 17000 nM
Beside the measured number, compound 3's estimate is 3.4-fold (0.53 log units) below it, within the range that was stated.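

Here the position answers to the change: 4-chlorophenyl to 4-hydroxyphenyl in this assay gives a 2.7-fold higher number from compound 2 to compound 3 (0.43 log units; beyond the scatter). Going by these compounds alone, of this pair, the chloro form is the stronger inhibitor, and the step in this assay is the first one that can be read for the series. The reading for compound 1 is a limit and not a number, and little readable room remains for weaker analogues: the limit of > 20000 nM in this assay, at which 1 of the 3 values shown sits.

As far as these compounds go, whether this step is specific to hydroxy or would follow any replacement of chloro remains open. An amine or a carboxylic acid at this place is not among the compounds shown.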